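A few compounds are considered here, and "the series" means these few. Any claim that something is new, unique, unknown or untested is made for them only; others in the source may bear on it.

Of the compounds shown here, three with one shared core have been tested in a functional assay on the whole organism (strain BALB/c) with Mus musculus as the target, with a stated time of 4 h; a higher number here means that more compound is needed for the effect, a lower number that less compound is needed. The starting point is compound 1 `CC1=C(CN2CC(C(=O)O)C2)CCc2cc(OCC3Cc4ccccc4C3)ccc21`. Compound 1 gives > 1 mg/kg, which is a limit of the assay and not a number. Its true position on the scale is therefore unknown, and any comparison with it has to stay loose.

Two relatives do give numbers. Compound 2 `COc1cc(COc2ccc3c(c2)CCC(CN2CC(C(=O)O)C2)=C3C)ccc1CC(C)C` gives 0.034 mg/kg, and compound 3 `CC1=C(CN2CC(C(=O)O)C2)CCc2cc(OCc3ccc(CC(C)C)cc3F)ccc21` gives 0.073 mg/kg. Each carries a substituted phenyl group on the saturated chain carbon where compound 1 has its 2,3-dihydro-1H-inden-2-yl group.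

Compound 4 `CCc1ccc(COc2ccc3c(c2)CCC(CN2CC(C(=O)O)C2)=C3C)c(OC)c1` keeps the core of compound 1 and changes one group: 4-ethyl-2-methoxyphenyl in place of 2,3-dihydro-1H-inden-2-yl on a saturated chain carbon bound to an oxygen on an aromatic ring. Among the compounds with values here, no pair of measured compounds isolates this change, so the forecast leans on the resemblance to compound 2, at 0.034 mg/kg, and compound 3, at 0.073 mg/kg. Neither carries the 4-ethyl-2-methoxyphenyl group itself, so the range must stay wide.

A clear move towards less compound needed is expected in this assay, with an estimated size of an at least 6.6-fold lower number from compound 1 to compound 4 (0.82 log units; beyond the scatter). For compound 4 the estimated value is 0.15 mg/kg, with an expected range from 0.04 mg/kg to 0.6 mg/kg.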

Compound 4, dose for half-maximal effect: 0.026 mg/kg
For compound 4 the middle estimate is 5.8-fold (0.76 log units) above the measured one, outside the stated range (below it).
By their numbers in this assay, from the lowest: compounds 4 and 2 (each within the scatter of the next); then compound 3. At a limit, above all of these: compound 1.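

In this assay, putting 4-ethyl-2-methoxyphenyl in place of 2,3-dihydro-1H-inden-2-yl on a saturated chain carbon bound to an oxygen on an aromatic ring, with the rest of compound 1 unchanged, gives an at least 38-fold lower number from compound 1 to compound 4 (1.58 log units; beyond the scatter). Within the data shown here, this is the first step in the set that isolates one change in one place, so the large gain can be tied directly to this group exchange rather than only suggested by resemblance among relatives. The true size of the step stays open because compound 1 stands at a limit of the assay and not at a number: the limit of > 1 mg/kg in this assay, at which 1 of the 4 values shown sits.

The compounds shown do not settle how much of the step belongs to the ethyl group and how much to the methoxy group on the phenyl ring, as no pair separates the two. They also leave open how this assay would respond to a nitrile or a trifluoromethyl group in place of the ethyl group, or to an amine in place of the methoxy group.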